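Moving the ring nitrogen and restoring chlorine on the amide

The compounds below may be only part of what the source reports. "The series", "measured", "known", "first", "only" and "open" are said of these compounds alone.

Compound 2 `O=C(c1ccccn1)N1CCC(NS(=O)(=O)c2cc(S(=O)(=O)c3ccccc3)ccc2C(F)(F)F)CC1` gives 60 nM in an assay on isolated protein for displacement of a labelled ligand from secreted frizzled-related protein 1 (Homo sapiens), read by fluorescence polarization, with a stated time of 30 min (on this read-out higher numbers stand for weaker inhibition and lower numbers for stronger inhibition), the lowest of the two numbers recorded, while compound 1 `O=C(c1ccc(Cl)cc1)N1CCC(NS(=O)(=O)c2cc(S(=O)(=O)c3ccccc3)ccc2C(F)(F)F)CC1` gives 300 nM. Among the measured compounds shown here, the single measured step, a 5.0-fold lower number from compound 1 to compound 2 (0.70 log units; beyond the scatter), concerns a change that compound 3 `O=C(c1ccc(Cl)nc1)N1CCC(NS(=O)(=O)c2cc(S(=O)(=O)c3ccccc3)ccc2C(F)(F)F)CC1` partly reverses: the change is 6-chloropyridin-3-yl in place of pyridin-2-yl on a carbonyl carbon. For the measured compounds named here, no measured step covers this exact change, so the only guide is that compound 1, which also carries chlorine on its ring, gave 300 nM. Compound 3 is therefore expected to fall between the two, a step of a 2.5-fold higher number from compound 2 to compound 3 (0.40 log units; beyond the scatter) towards a higher number. The estimate for compound 3 is 150 nM, within 50 nM to 500 nM.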

Compound 3, half-maximal inhibitory concentration: 110 nM
Beside the measured number, compound 3's estimate is 1.4-fold (0.13 log units) above it, and the stated range covers the measured number.
By their numbers in this assay, from the lowest: compounds 2 and 3 (each within the scatter of the next); then compound 1.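

With chlorine on the ring, the 6-chloropyridin-3-yl group stays level with the pyridin-2-yl group on this carbonyl carbon, with a 1.8-fold higher number from compound 2 to compound 3 (0.26 log units; within the scatter) showing no separation between the two. Both chlorinated rings can now be compared, and a 2.7-fold lower number from compound 1 to compound 3 (0.44 log units; beyond the scatter) shows that chlorine alone does not fix the weaker number of compound 1, since the pyridine ring gives the lower reading. Nothing available explains either step. Still open, from the compounds shown here alone, is how pyridin-3-yl without chlorine would read here, which would separate the effect of the chlorine from that of the ring nitrogen's place. A 6-methylpyridin-3-yl or 6-methoxypyridin-3-yl group would show whether chlorine can be exchanged at all.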